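The source may hold more compounds than are shown below. What is called first, only, known or untested is meant among the compounds shown, and "the series" means these compounds.

In an ADME assay on microsomes from liver (Mus musculus) for metabolic stability (a higher number here means faster removal of the compound, a lower number slower removal), three compounds sharing one core have been measured so far: compound 1 (`COc1ccc(Cl)cc1OC1CN(S(=O)(=O)c2ccc3scnc3c2)C1`) gives 514 mL.min-1.g-1, compound 2 (`COc1ccc(Cl)cc1OC1CN(S(=O)(=O)c2ccc3cn[nH]c3c2)C1`) gives 2210 mL.min-1.g-1, and compound 3 (`COc1ccc(Cl)cc1OC1CN(S(=O)(=O)c2ccc3[nH]ncc3c2)C1`) gives 939 mL.min-1.g-1. Compound 3 lies within the usual scatter of compound 1 and clearly below compound 2. Compound 4 (`COc1ccc(Cl)cc1OC1CN(S(=O)(=O)c2ccc3c(cnn3C)c2)C1`) differs from compound 3 in one place: methyl in place of hydrogen on an aromatic nitrogen. Within the data shown here, no measured pair shows this change, so the expectation is tentative: a slight rise, with nothing beyond the scatter. The estimated move is small, a 1.3-fold higher number from compound 3 to compound 4 (0.11 log units; within the scatter). For compound 4 the expected value is 1200 mL.min-1.g-1, with an estimated range of 500 mL.min-1.g-1 to 2800 mL.min-1.g-1.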

Compound 4, intrinsic clearance in microsomes: 883 mL.min-1.g-1
Beside the measured number, compound 4's estimate is 1.4-fold (0.13 log units) above it, and the stated range covers the measured number.
By their numbers in this assay, from the lowest: compounds 1, 4 and 3 (each within the scatter of the next); then compound 2.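

In this assay, methyl in place of hydrogen on an aromatic nitrogen gives a 1.1-fold lower number from compound 3 to compound 4 (0.03 log units; within the scatter) and so leaves the number effectively unchanged. At this position, then, the hydrogen on the nitrogen can give way to one small carbon group with no readable effect on removal in microsomes. Nothing shown here gives a reason for this result. Still open, from the compounds shown here alone, is whether a longer chain on this nitrogen, or one ending in an amine or a carboxylic acid, would leave the number just as unchanged.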